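Imidazolyl for methyltriazolyl: from compound 1 to compound 4

This account rests on a few compounds, and the source may have more. Where it says the series, first, only, none or still open, it means among the compounds named here.

Measured so far in an assay on microsomes from intestine for inhibition of acyl-CoA:cholesterol acyltransferase (Oryctolagus cuniculus); on this read-out higher numbers stand for weaker inhibition and lower numbers for stronger inhibition:
compound 1 `Cc1cc(C)c(NC(=O)N(Cc2ccc(-c3n[nH]c(C)n3)cc2)C2CCCCCC2)c(C)c1` gives 120 nM
compound 2 `O=C(Nc1c(F)cc(F)cc1F)N(Cc1cccc(-c2cc[nH]n2)c1)C1CCCCCC1` gives 22 nM
compound 3 `Cc1cc(C)c(NC(=O)N(Cc2cccc(-c3cn[nH]c3)c2)C2CCCCCC2)c(C)c1` gives 38 nM

Compound 1 has the highest number of the three in this assay. Compound 3 stands nearest to it and compound 2 furthest; both have lower numbers, and both gaps lie beyond the usual scatter. Neither compound 2 nor compound 3 differs from compound 1 in a single place, so their lower numbers cannot be tied to any one part of the structure.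

Compound 4 `Cc1cc(C)c(NC(=O)N(Cc2ccc(-n3ccnc3)cc2)C2CCCCCC2)c(C)c1` is the next compound to be tested. It differs from compound 1 as follows: 1H-imidazol-1-yl in place of 5-methyl-1H-1,2,4-triazol-3-yl on an aromatic carbon. For the measured compounds named here, no measured pair isolates this kind of change, so there is no step in the data to lean on. The step from compound 1 to compound 4 in this assay is expected to be a 1.3-fold higher number from compound 1 to compound 4 (0.10 log units; within the scatter), that is, nothing clearly beyond the scatter in either direction. Compound 4 is accordingly estimated at 150 nM, with a range from 50 nM to 450 nM.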

Compound 4, half-maximal inhibitory concentration: 47 nM
Estimate against measurement, compound 4: 3.2-fold (0.50 log units) above, outside the stated range (below it).
By their numbers in this assay, from the lowest: compounds 2, 3 and 4 (each within the scatter of the next, the first and the last beyond it); then compound 1.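

In this assay, for the compounds shown here, replacing 5-methyl-1H-1,2,4-triazol-3-yl with 1H-imidazol-1-yl gives a 2.6-fold lower number from compound 1 to compound 4 (0.41 log units; beyond the scatter), the first step that can be tied to one place, and it shows that the group on this aromatic carbon, para to a large group, bears on the number. The entering group carries no hydrogen-bond donor, so a donor in this group is not required for compound 4 to reach 47 nM. No measurement at hand accounts for the step.

On these data alone, this one change swaps the ring, removes the methyl and removes the donor together, so which of these carries the difference stays open. Also open, as far as these compounds go, is how an amine or a carboxylic acid on this aromatic carbon would read in this assay.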